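The source may report more compounds than this note shows. Statements on the series, on what has been measured and on what is new or still open speak of the compounds shown alone.

Measured compounds:
- compound 1 `CCCCCCCCCCCCCCNC(=O)[C@@H](N)[C@@H](C)O` — 10700 nM
- compound 2 `CCCCCCCCCCCCCCCCCCNC(=O)[C@@H](N)[C@@H](C)O` — 27400 nM
- compound 3 `CCCCCCCCCCCCNC(=O)[C@@H](NC(=O)c1cc2ccccc2o1)[C@@H](C)O` — 20900 nM

In a functional assay on MCF7 cells (Homo sapiens) for cytotoxicity, read by MTT assay, with a stated time of 48 h (a higher number here means a weaker inhibitor, a lower number a stronger inhibitor), compound 1 gives the lowest number of the three. Compound 2 lies further away, with a 2.6-fold higher number from compound 1 to compound 2 (0.41 log units; beyond the scatter), where the change is butyl in place of hydrogen on a saturated chain carbon, ten or more bonds along the chain from an amide-type nitrogen. Among the compounds with values here, compound 3, which carries an acyl group on the amine nitrogen and a shorter chain, gives a number within the scatter of compound 1; no single-place step connects these two, so only the two values can be compared.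

Compound 4 `CCCCCCCCCCCCCCNC(=O)[C@@H](NC(=O)/C=C/c1ccccc1)[C@@H](C)O` is not yet measured. It differs from compound 1 by (2-phenylethenyl)carbonyl in place of hydrogen on an amine nitrogen. Within the data shown here, no measured step addresses an acylation of this nitrogen on its own. The nearest information is compound 3, whose value sits within the scatter of compound 1 despite an acyl group on that nitrogen together with a shorter chain. On that basis compound 4 is expected to give a number close to that of compound 1, with a 1.4-fold higher number from compound 1 to compound 4 (0.15 log units; within the scatter) not clearly beyond the scatter. The estimate for compound 4 in this assay is 15000 nM, within 6000 nM to 40000 nM.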

Compound 4, half-maximal inhibitory concentration: 64600 nM
Compound 4: middle estimate off by 4.3-fold (0.63 log units), on the low side, and the stated range ends below it.
By their numbers in this assay, from the lowest: compounds 1, 3 and 2 (each within the scatter of the next, the first and the last beyond it); then compound 4.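

In this assay, within the data shown here, (2-phenylethenyl)carbonyl in place of hydrogen on the amine nitrogen gives a 6.0-fold higher number from compound 1 to compound 4 (0.78 log units; beyond the scatter), the first reading at this position in which nothing else changes. On the chain of compound 1, acylating this nitrogen with this group therefore gives a weaker inhibitor, and the amine hydrogen cannot be swapped for it without a measurable shift. No measurement at hand explains the shift.

Going by these compounds, whether the shift belongs to acylation as such or to this particular group remains open; compound 3 carries a different acyl group on a shorter chain, so it cannot settle the point. An acetyl, benzoyl or saturated 3-phenylpropanoyl group on this nitrogen, with the chain of compound 1 kept, would separate the acyl carbonyl from the phenyl ring and the chain double bond.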